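Propyl in Place of Bromo on a Shared Core

The source may report more compounds than this note shows. Statements on the series, on what has been measured and on what is new or still open speak of the compounds shown alone.

Among the compounds with values here, in a functional assay on Jurkat cells (Homo sapiens) for cytotoxicity, with a stated time of 48 h (on this read-out lower numbers stand for stronger inhibition and higher numbers for weaker inhibition), compound 1 (`CCOC(=O)CC1C(C(=O)OCC)=C(N)Oc2ccccc21`) gives 91400 nM and compound 2 (`CCOC(=O)CC1C(C(=O)OCC)=C(N)Oc2ccc(Br)cc21`) gives 57300 nM on the same read-out, so compound 2 stands level with the only other measured compound. Compound 3 (`CCCc1ccc2c(c1)C(CC(=O)OCC)C(C(=O)OCC)=C(N)O2`) differs from compound 2 by propyl in place of bromo on an aromatic carbon with propyl in place of bromo on an aromatic carbon. Within the data shown here, the one measured step that bears on this is a 1.6-fold lower number from compound 1 to compound 2 (0.20 log units; within the scatter) for bromo in place of hydrogen on an aromatic carbon. Among the measured compounds shown here, with so small a step as the only guide, no shift beyond the scatter is expected in this assay here. The estimated step is a 1.1-fold lower number from compound 2 to compound 3 (0.06 log units; within the scatter) for this swap. Compound 3 is expected at 50000 nM with an estimated range from 20000 nM to 110000 nM for now.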

Compound 3, half-maximal inhibitory concentration: 57300 nM
Compound 3: middle estimate off by 1.1-fold (0.06 log units), on the low side; measured number inside the range.
By their numbers in this assay, from the lowest: compounds 2, 3 and 1 (each within the scatter of the next).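

On an aromatic carbon of the shared core, propyl in place of bromo gives no change at the digits printed from compound 2 to compound 3 (within the scatter) in this assay, and propyl in place of hydrogen gives a 1.6-fold lower number from compound 1 to compound 3 (0.20 log units; within the scatter) for the same carbon. Hydrogen, bromo and propyl therefore all read alike here, so a chain of three carbons shifts the number no further than the scatter, just as bromo did. No other measurement available here helps to interpret this result. On these data alone, whether an amine or a carboxylic acid on this carbon would move the number beyond the scatter stays open.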